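A few compounds are considered here, and "the series" means these few. Any claim that something is new, unique, unknown or untested is made for them only; others in the source may bear on it.

Compound 1 `O=C1CCCCC/C1=C\c1cccc(F)c1` and compound 2 `O=C1CCCCC/C1=C\c1ccc(F)cc1` are built from the same atoms joined differently; the difference between the two cores is not broken down here. In a functional assay on MOLT-4 cells (Homo sapiens) for inhibition (a lower number here means a stronger inhibitor, a higher number a weaker inhibitor), compound 1 gives 482000 nM, and compound 2 gives 250000 nM; these two values lie within the scatter of each other. Compound 3 `O=C1CCCCC/C1=C\c1cccc(Cl)c1` gives 88600 nM in this assay, and the step of a 5.4-fold lower number from compound 1 to compound 3 (0.74 log units; beyond the scatter) rests on the change (chloro in place of fluoro on an aromatic carbon). Compound 4 `O=C1CCCCC/C1=C\c1ccc(Cl)cc1` is not yet measured; it differs from compound 2 by chloro in place of fluoro on an aromatic carbon, the same kind of change, here para to a group of 9 heavy atoms rather than meta to a group of 9 heavy atoms. Because the earlier step of a 5.4-fold lower number from compound 1 to compound 3 (0.74 log units; beyond the scatter) was modest, a step of similar size, a 5.0-fold lower number from compound 2 to compound 4 (0.70 log units; beyond the scatter), is expected. For compound 4 in this assay the estimate is 50000 nM, expected between 20000 nM and 125000 nM.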

Compound 4, half-maximal inhibitory concentration: 52600 nM
For compound 4 the middle estimate is 1.1-fold (0.02 log units) below the measured one; low and high end bracket the measured number.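

Chloro in place of fluoro on an aromatic carbon gives a 4.8-fold lower number from compound 2 to compound 4 (0.68 log units; beyond the scatter) in this assay. Set beside the earlier step, the change carries from one core to the other with no difference beyond the scatter: the same change on two cores in this assay, a 5.4-fold lower number (0.74 log units; beyond the scatter) from compound 1 to compound 3 and a 4.8-fold lower number (0.68 log units; beyond the scatter) from compound 2 to compound 4, 1.1-fold (0.06 log units) apart, within the scatter of two such steps. This agreement rests on two pairs alone and gives no reason for the step; it does not show that the step would hold on a core that differs in more than the place of the substituent.

As far as these compounds go, how bromo, methoxy or trifluoromethyl in the same places would compare remains open. So does the effect of an amine or a carboxylic acid on the aromatic ring.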